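Methoxy to Nitro: Expected Cell Tolerance for Compound 3

This account rests on a few compounds, and the source may have more. Where it says the series, first, only, none or still open, it means among the compounds named here.

Compound 2 `COc1ccc(CSc2nc(Cc3cc(C(F)(F)F)cc(C(F)(F)F)c3)c(C)c(=O)[nH]2)cc1` was tested in an ADME assay on MT4 cells (Homo sapiens) for cytotoxicity, read by MTT assay (a higher number here means that more compound is tolerated, a lower number that less compound is tolerated), where compound 2 gives > 256000 nM, which is a limit of the assay rather than a number. Its companion compound 1 `COc1ccc(CSc2nc(Cc3cc(C)cc(C)c3)c(C)c(=O)[nH]2)cc1` likewise reaches only a limit in this assay, giving > 329000 nM. Compound 3 `Cc1c(Cc2cc(C(F)(F)F)cc(C(F)(F)F)c2)nc(SCc2ccc([N+](=O)[O-])cc2)[nH]c1=O` differs from compound 2 by nitro in place of methoxy on an aromatic carbon. Since both measured values sit at limits, as the limit of > 256000 nM in this assay, at which 1 of the 2 values shown sits, and the limit of > 329000 nM in this assay, at which 1 of the 2 values shown sits, show, no step beyond the scatter is expected, and the step is estimated at an at least 1.0-fold lower number from compound 2 to compound 3 (0.01 log units; that floor lies within the scatter). Compound 3 is therefore expected to give about 250000 nM, within 100000 nM to 400000 nM.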

Compound 3, half-maximal cytotoxic concentration: > 248000 nM
Compound 3: no number, only a limit; the forecaster's own chance of this, stated with the estimate: 75%; the middle value lies beyond the limit too.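

Among the compounds shown here, compound 2 and compound 3 both reach only a limit in this assay, so no step between them can be read. The compounds shown leave open whether nitro in place of methoxy on an aromatic carbon changes how much compound is tolerated.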